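Dropping the chloro from compound 1: what to expect

The source may hold more compounds than are shown below. What is called first, only, known or untested is meant among the compounds shown, and "the series" means these compounds.

Compound 1: `OC[C@H]1C[C@@H](Cn2cnc3c(-c4ccc(Cl)cc4)ncnc32)c2ccccc21` — 8440 nM
Compound 2: `O[C@H]1C[C@@H](Cn2cnc3c(Cl)ncnc32)c2ccccc21` — > 200000 nM

The two measured compounds were tested in an ADME assay on L1210/0 cells (Mus musculus) for cytotoxicity, with a stated time of 48 h; a lower number here means a stronger inhibitor, a higher number a weaker inhibitor. Compound 1 gives 8440 nM in this assay. Compound 2 reaches only a limit of the assay, > 200000 nM, so no number is known for it. Going by the values given here, compound 1 therefore holds the only number in this assay; the other value is a limit, as set out in the limit of > 200000 nM in this assay, at which 1 of the 2 values shown sits. Among the compounds with values here, compound 2 differs from compound 1 in more than one place, so no single step between them can be drawn, and their two values show only that compound 1 gives a number where compound 2 gives a limit.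

The step followed here goes from compound 1 to compound 3, `OC[C@H]1C[C@@H](Cn2cnc3c(-c4ccccc4)ncnc32)c2ccccc21`, which has not yet been measured in this assay. The change is hydrogen in place of chloro on an aromatic carbon. Within the data shown here, no measured pair shows this kind of change, so there is no basis for a measured step. In this assay the step from compound 1 to compound 3 is expected to be small, at most modestly towards a weaker inhibitor, at a 1.8-fold higher number from compound 1 to compound 3 (0.25 log units; within the scatter). Compound 3 is therefore estimated at 15000 nM, with a range from 4000 nM to 60000 nM.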

Compound 3, half-maximal inhibitory concentration: 28100 nM
Beside the measured number, compound 3's estimate is 1.9-fold (0.27 log units) below it; low and high end bracket the measured number.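

In this assay, going by these compounds alone, hydrogen in place of chloro gives a 3.3-fold higher number from compound 1 to compound 3 (0.52 log units; beyond the scatter), the first single change that can be read, and it places 4-chlorophenyl at the lower number of this pair. The step lies beyond the scatter but is modest: without the chloro on this aromatic carbon, para to a large group, compound 3 still gives a measured number and not a limit, at 28100 nM in this assay. Nothing measured here bears on why removing the chloro has this effect.

The compounds shown leave open whether this step is particular to chloro or whether other groups at this place, such as fluoro, methoxy, an amine or a carboxylic acid, would give numbers nearer to compound 1 or to compound 3. Within the data shown here, they also leave open what the hydroxymethyl group and the 4-chlorophenyl group each contribute alone, since compound 2 differs from compound 1 in more than one place and no single step connects them.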